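Removing a Phenyl from Compound 1

The source may report more compounds than this note shows. Statements on the series, on what has been measured and on what is new or still open speak of the compounds shown alone.

The series shares one core and varies the group carried on the pendant ring. Compound 1 `Nc1cc(Cc2ccn(Cc3cccc(-c4ccccc4)c3)n2)c2nn[nH]c2n1` gives 55 nM in an assay on isolated protein for inhibition of Myeloperoxidase (Homo sapiens), with a stated time of 10 min; on this read-out higher numbers stand for weaker inhibition and lower numbers for stronger inhibition. For the measured compounds named here, compound 2 `Nc1cc(Cc2ccn(Cc3ccc4ccccc4c3)n2)c2nn[nH]c2n1` gives 52 nM, a number that sits within the scatter of the one for compound 1. Going by the values given here, compound 3 `Nc1cc(C2CCNC34CCC(c5ccccc5)(CC3)[C@H](C4)Oc3cccc(c3)Cn3cc2cn3)c2nn[nH]c2n1`, a macrocyclic member of the set, gives 7 nM, and this is the only value that stands beyond the scatter from compound 1; the number for compound 1 is the highest of the three, so on this read-out compound 1 is no stronger an inhibitor than any other member measured.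

Compound 4 `Nc1cc(Cc2ccn(Cc3ccccc3)n2)c2nn[nH]c2n1` has not yet been measured. Relative to compound 1 it differs by hydrogen in place of phenyl on an aromatic carbon. Among the compounds with values here, no step between two measured compounds matches this change, so its size can only be guessed. Since a whole phenyl is lost, the step is expected to raise the number, and the estimate for compound 4 is 150 nM with a range of 50 nM to 500 nM. That estimate means a step of a 2.7-fold higher number from compound 1 to compound 4 (0.44 log units; beyond the scatter) toward weaker inhibition, though a change within the scatter cannot be ruled out.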

Compound 4, half-maximal inhibitory concentration: 120 nM
Compound 4: middle estimate off by 1.3-fold (0.10 log units), on the high side; the range from low to high includes it.
By their numbers in this assay, from the lowest: compound 3; then compounds 2 and 1 (each within the scatter of the next); then compound 4.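

In this assay, for the compounds shown here, hydrogen in place of phenyl on an aromatic carbon gives a 2.2-fold higher number from compound 1 to compound 4 (0.34 log units; beyond the scatter), the first change at a single place that can be read in this set. The step is modest but lies beyond the scatter, so the phenyl at this position does bear on the number, yet with 6 heavy atoms gone compound 4 still gives 120 nM. Nothing shown here accounts for the size of this step.

As far as these compounds go, it remains open whether the step belongs to the phenyl itself or would follow from any group on this carbon: a methyl, a methoxy or a chlorine there would tell these readings apart. Going by these compounds alone, no other single-place step is available, so how this position compares with the rest of the series cannot be read.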